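Swapping phenyl for 2-hydroxyethyl on a weak inhibitor

A few compounds are considered here, and "the series" means these few. Any claim that something is new, unique, unknown or untested is made for them only; others in the source may bear on it.

Measured in a functional assay for inhibition, with Homo sapiens as the target; a higher number here means a weaker inhibitor, a lower number a stronger inhibitor:
Compound 1 `O=C(O)COc1cccc(CC(C(=O)O)c2nc(-c3ccccc3)c(-c3ccccc3)o2)c1`: 14000 nM
Compound 2 `C[S+]([O-])C(Cc1cccc(OCC(=O)O)c1)c1nc(-c2ccccc2)c(-c2ccccc2)o1`: 7080 nM
Compound 3 `O=C(O)COc1cccc(CC(c2ccccc2)c2nc(-c3ccccc3)c(-c3ccccc3)o2)c1`: 23200 nM

These three compounds share one core and differ only in the group on a single saturated chain carbon. Compound 3 reads 23200 nM, and its nearest neighbour on the numbers is compound 1. That gap, a 1.7-fold higher number from compound 1 to compound 3 (0.22 log units; within the scatter), is no real difference. The one clear separation is a 3.3-fold higher number from compound 2 to compound 3 (0.52 log units; beyond the scatter).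

The next molecule, compound 4 `O=C(O)COc1cccc(CC(CCO)c2nc(-c3ccccc3)c(-c3ccccc3)o2)c1`, changes that same carbon: 2-hydroxyethyl in place of phenyl on a saturated chain carbon bound to an aromatic carbon and a saturated chain carbon. In words, 2-hydroxyethyl replaces phenyl. Among the compounds with values here, no measured compound carries this group, so the evidence is indirect.

Within the data shown here, the steps at this carbon are the only guide, and all of them are small. Replacing phenyl with the group of compound 2 matters modestly, as a 3.3-fold higher number from compound 2 to compound 3 (0.52 log units; beyond the scatter) shows. Compound 1 goes against any firm rule that losing phenyl lowers the number, since a 1.7-fold higher number from compound 1 to compound 3 (0.22 log units; within the scatter) stays within the scatter, as does a 2.0-fold lower number from compound 1 to compound 2 (0.30 log units; within the scatter). A small drop at most therefore seems likely, with no large move in either direction. The expected change is a 1.9-fold lower number from compound 3 to compound 4 (0.29 log units; within the scatter), which would be a slight shift toward a lower number. For compound 4 the estimated value is 12000 nM, with an expected range from 5000 nM to 28000 nM.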

Compound 4, half-maximal inhibitory concentration: 2920 nM
Beside the measured number, compound 4's estimate is 4.1-fold (0.61 log units) above it, outside the stated range (below it).
By their numbers in this assay, from the lowest: compound 4; then compounds 2, 1 and 3 (each within the scatter of the next, the first and the last beyond it).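

In this assay this carbon proves more sensitive than the first three compounds suggested, as replacing phenyl with 2-hydroxyethyl gives a 7.9-fold lower number from compound 3 to compound 4 (0.90 log units; beyond the scatter) and that step is larger than any seen among those three. Compound 4 also stands apart from the two other compounds without phenyl, with a 2.4-fold lower number from compound 2 to compound 4 (0.38 log units; beyond the scatter) and with a 4.8-fold lower number from compound 1 to compound 4 (0.68 log units; beyond the scatter) as well, which makes it the strongest inhibitor of the four and shows that removing phenyl is not enough on its own to reach this level. The 2-hydroxyethyl group brings one hydrogen-bond donor and one acceptor where phenyl has none, yet this is only a count, and no measurement here explains the drop in the number.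

The compounds shown leave open whether the hydroxyl is needed at all, a question that a plain ethyl chain at the same carbon would help to answer. They also leave open whether a longer chain such as 3-hydroxypropyl, or an amine in place of the hydroxyl, would move the number further in the same direction.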